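Replacing the methoxyphenyl amide with a nitrophenyl amide

A few compounds are considered here, and "the series" means these few. Any claim that something is new, unique, unknown or untested is made for them only; others in the source may bear on it.

Three amides built on one shared core have been measured in an assay on isolated protein for inhibition of Rho-associated protein kinase 1 (Homo sapiens), read by scintillation counting, radiometric assay and 33P incorporation, with a stated time of 40 min, in the presence of a further agent that is not named here; on this read-out higher numbers stand for weaker inhibition and lower numbers for stronger inhibition. Compound 1 `CCCc1ccc(C(=O)Nc2cccc(NC(=O)COc3ccc4c(=O)ccoc4c3)c2)cc1` gives 143 nM, compound 2 `CC(C)(C)c1ccc(C(=O)Nc2cccc(NC(=O)COc3ccc4c(=O)ccoc4c3)c2)cc1` gives 165 nM, and compound 3 `COc1ccc(C(=O)Nc2cccc(NC(=O)COc3ccc4c(=O)ccoc4c3)c2)cc1` gives 18 nM, the lowest of the three numbers. The steps of a 7.9-fold lower number from compound 1 to compound 3 (0.90 log units; beyond the scatter) and a 9.2-fold lower number from compound 2 to compound 3 (0.96 log units; beyond the scatter) both lead to the methoxy compound and lower the number, whereas a 1.2-fold higher number from compound 1 to compound 2 (0.06 log units; within the scatter) stays within the scatter. Compound 4 `O=C(COc1ccc2c(=O)ccoc2c1)Nc1cccc(NC(=O)c2cccc([N+](=O)[O-])c2)c1` differs from compound 3 by 3-nitrophenyl in place of 4-methoxyphenyl on a carbonyl carbon. Within the data shown here, no measured step covers a nitro group; the steps that bear on the change are only those reaching methoxy, and leaving methoxy behind is therefore expected to cost potency. An upward step of a 5.6-fold higher number from compound 3 to compound 4 (0.74 log units; beyond the scatter) is expected. The estimate for compound 4 is 100 nM, within a range from 30 nM to 400 nM.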

Compound 4, half-maximal inhibitory concentration: 528 nM
Beside the measured number, compound 4's estimate is 5.3-fold (0.72 log units) below it, and the stated range ends below it.
By their numbers in this assay, from the lowest: compound 3; then compounds 1 and 2 (each within the scatter of the next); then compound 4.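

In this assay, among these compounds, 3-nitrophenyl in place of 4-methoxyphenyl gives a 29-fold higher number from compound 3 to compound 4 (1.47 log units; beyond the scatter), a larger step than any among the earlier compounds. The new group also falls behind both alkyl-bearing amides, with a 3.7-fold higher number from compound 1 to compound 4 (0.57 log units; beyond the scatter) and a 3.2-fold higher number from compound 2 to compound 4 (0.51 log units; beyond the scatter), so the range at this position extends well past what those compounds showed. Nothing measured here explains the loss. Still open, from the compounds shown here alone, is whether the nitro group or its place on the ring carries the step, which 4-nitrophenyl or 3-methoxyphenyl would separate. Going by these compounds, how a 3-aminophenyl amide would read is also open.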